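The compounds below may be only part of what the source reports. "The series", "measured", "known", "first", "only" and "open" are said of these compounds alone.

In a functional assay on THP-1 cells (Homo sapiens) for inhibition, read by sulforhodamine B assay, with a stated time of 48 h (on this read-out lower numbers stand for stronger inhibition and higher numbers for weaker inhibition), the measured compounds are:
Compound 1 `CCOC(=O)CCO/N=C(/c1ccc(OC)c(OC)c1OC)c1cccc2ccccc12`: > 20000 nM, a limit of the assay.
Compound 2 `CCOC(=O)C(C)C(O)(c1ccc(OC)c(OC)c1OC)c1cccc2ccccc12`: > 20000 nM, a limit of the assay.
Compound 3 `COc1ccc(C(O)(Cc2ccc(F)cc2)c2cccc3ccccc23)c(OC)c1OC`: 5860 nM.

Compound 3 thus stands as the only number shown; the other two values sit at the limit of > 20000 nM in this assay, at which 2 of the 3 values shown sit. Going by the values given here, the single measured step is an at least 3.4-fold lower number from compound 2 to compound 3 (0.53 log units; beyond the scatter), and it moves from a limit to a number. Compound 4 `COc1ccc(C(O)(C/C=C\c2ccccc2)c2cccc3ccccc23)c(OC)c1OC` differs from compound 3 by 2-phenylethenyl in place of 4-fluorophenyl on a saturated chain carbon, two bonds along the chain from two aromatic carbons and an oxygen on a saturated carbon. Among the compounds with values here, no measured step covers this change, so the expectation rests on compound 3 alone, and the step of a 1.2-fold lower number from compound 3 to compound 4 (0.07 log units; within the scatter) is expected to stay within the scatter. Compound 4 is therefore estimated at 5000 nM in this assay, with a range from 1500 nM to 16000 nM.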

Compound 4, half-maximal inhibitory concentration: 19400 nM
Estimate against measurement, compound 4: 3.9-fold (0.59 log units) below; the measured number lies above the stated range.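

At this position the group carried by the chain matters: 2-phenylethenyl in place of 4-fluorophenyl gives a 3.3-fold higher number from compound 3 to compound 4 (0.52 log units; beyond the scatter). The lower number seen earlier, an at least 3.4-fold lower number from compound 2 to compound 3 (0.53 log units; beyond the scatter), therefore does not extend to every chain ending in an aromatic ring, since 3-phenylprop-2-en-1-yl keeps little of it. Only a floor can be read for the remaining step (an at least 1.0-fold lower number from compound 2 to compound 4 (0.01 log units; that floor lies within the scatter)) because one of its two values is a limit: the limit of > 20000 nM in this assay, at which 2 of the 4 values shown sit.

Still open, from the compounds shown here alone, is whether the fluorine or the double bond carries the step, which a plain benzyl group would separate. Going by these compounds, how an amine or a carboxylic acid on this chain would read also remains open.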